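A few compounds are considered here, and "the series" means these few. Any claim that something is new, unique, unknown or untested is made for them only; others in the source may bear on it.

Series notes. Compound 1 `CN1CCNC(=O)COc2ccc(F)cc2C(=O)N2CCCC[C@H]2c2cc3nc(N4CCC4)cc1n3n2` gives 80 10^-6 cm/s in an ADME assay for permeability, using PAMPA, with a stated time of 4 h; a higher number here means that the compound crosses the layer faster, a lower number that the compound crosses the layer more slowly. Compound 2 `CN1CCNC(=O)COc2ccc(F)cc2C(=O)N2CCCC[C@H]2c2cc3nc(N4CC(N)C4)cc1n3n2` gives 3.3 10^-6 cm/s in this assay, and compound 3 `CNC1CN(c2cc3n4nc(cc4n2)[C@@H]2CCCCN2C(=O)c2cc(F)ccc2OCC(=O)NCCN3C)C1` gives 5.9 10^-6 cm/s. Compound 2 stands at the low end of the three numbers: its gap to compound 3 is within the scatter, whereas a 24-fold lower number from compound 1 to compound 2 (1.38 log units; beyond the scatter) marks a large gap. Compound 4 `CN1CCNC(=O)COc2ccc(F)cc2C(=O)N2CCCC[C@H]2c2cc3nc(N4CC[C@H](N)C4)cc1n3n2` carries the change (3-aminopyrrolidin-1-yl in place of 3-aminoazetidin-1-yl on an aromatic carbon). Among the measured compounds shown here, no measured step covers a change of ring size. The large steps of a 24-fold lower number from compound 1 to compound 2 (1.38 log units; beyond the scatter) and a 14-fold lower number from compound 1 to compound 3 (1.13 log units; beyond the scatter) concern the amino and methylamino groups, both of which remain in compound 4, and a 1.8-fold higher number from compound 2 to compound 3 (0.25 log units; within the scatter) is a small step at the amine nitrogen. A step within the scatter is therefore expected, a 1.4-fold higher number from compound 2 to compound 4 (0.13 log units; within the scatter). Compound 4 is estimated at 4.5 10^-6 cm/s, range 2 10^-6 cm/s to 11 10^-6 cm/s.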

Compound 4, apparent permeability: 0.3 10^-6 cm/s
Compound 4: middle estimate off by 15-fold (1.18 log units), on the high side; the whole stated range lies above it.
By their numbers in this assay, from the lowest: compound 4; then compounds 2 and 3 (each within the scatter of the next); then compound 1.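

At this aromatic carbon, next to the ring nitrogen, ring size alone gives a large step in this assay (an 11-fold lower number from compound 2 to compound 4 (1.04 log units; beyond the scatter)), although the amino group stays and the counted hydrogen-bond donors and acceptors do not change. Compound 4 also stands well apart from the other two compounds (a 20-fold lower number from compound 3 to compound 4 (1.29 log units; beyond the scatter)) and (a 270-fold lower number from compound 1 to compound 4 (2.43 log units; beyond the scatter)), so the amino and methylamino steps did not mark the low end of the series.

Pyrrolidin-1-yl without the amino group, or 3-aminopiperidin-1-yl, at this carbon would show whether the step follows the ring alone or the ring together with the amino group. Nothing shown gives a reason for the step.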